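The compounds below may be only part of what the source reports. "The series", "measured", "known", "first", "only" and "open" are said of these compounds alone.

Measured so far in a functional assay on the whole organism with Mus musculus as the target; on this read-out lower numbers stand for an effect already at smaller amounts and higher numbers for an effect only at larger amounts of compound:
Compound 1 `CC(C)NCc1nnc(-c2ccccc2-c2ccccc2)s1`: 35 mg/kg
Compound 2 `NCc1nnc(-c2ccccc2-c2ccccc2)s1`: 22 mg/kg

For the measured compounds named here, compound 2 stands at one of only two numbers; compound 1 is the nearest, and the one step between them, a 1.6-fold lower number from compound 1 to compound 2 (0.20 log units; within the scatter), lies within the scatter, so the two numbers are not separated by this assay. That step changes the amine nitrogen, hydrogen in place of isopropyl.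

Compound 3 `CC(N)c1nnc(-c2ccccc2-c2ccccc2)s1` has not yet been measured. It differs from compound 2 by methyl in place of hydrogen on a saturated chain carbon bound to an amine nitrogen and an aromatic carbon. Going by the values given here, no measured step touches this chain carbon: the one known step sits on the amine nitrogen and was itself within the scatter. Nothing here points to a change beyond the scatter in either direction, and the expectation rests on compound 2 alone, because its value 22 mg/kg is the closest point of reference.

For compound 3 the expected value in this assay is 22 mg/kg, with a range from 11 mg/kg to 45 mg/kg. For compound 3 this means an expected no change at the digits printed from compound 2 to compound 3 (within the scatter), within the scatter.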

Compound 3, dose for half-maximal effect: 32 mg/kg
Estimate against measurement, compound 3: 1.5-fold (0.16 log units) below; the measured number falls inside the stated range.
By their numbers in this assay, from the lowest: compounds 2, 3 and 1 (each within the scatter of the next).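

In this assay, methyl in place of hydrogen on a saturated chain carbon bound to an amine nitrogen and an aromatic carbon gives a 1.5-fold higher number from compound 2 to compound 3 (0.16 log units; within the scatter), so this assay does not separate aminomethyl from 1-aminoethyl. For the compounds shown here, the one earlier step touched only the amine nitrogen, whereas this result shows that the chain carbon can also carry a methyl without a difference beyond the scatter, and 1-aminoethyl in place of (isopropylamino)methyl gives a 1.1-fold lower number from compound 1 to compound 3 (0.04 log units; within the scatter), which also lies within the scatter. Nothing available bears on the cause of these small differences.

As far as these compounds go, it remains open whether ethyl or a second methyl on this chain carbon, or a hydroxyl group in place of the methyl, would move the number beyond the scatter. Also open, from the compounds shown here alone, are whether the two mirror-image forms of compound 3 differ from each other and whether an isopropyl group on the amine nitrogen of compound 3 would leave its number within the scatter.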